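Compound 4: A New Group on the Aromatic Nitrogen

The source may hold more compounds than are shown below. What is called first, only, known or untested is meant among the compounds shown, and "the series" means these compounds.

compound 1 `Oc1cc(C(F)(F)F)ccc1-c1nc(-c2ccccc2O)n(-c2ccc(I)cc2)n1`: 70.1%
compound 2 `Oc1cc(C(F)(F)F)ccc1-c1nc(-c2ccccc2O)n(-c2ccc(OC(F)(F)F)cc2)n1`: 65.5%
compound 3 `Oc1cc(C(F)(F)F)ccc1-c1nc(-c2ccccc2O)n(-c2ccccc2Cl)n1`: 70.1%

In a functional assay on PC-12 cells (Rattus norvegicus) for cytotoxicity, read by MTT assay, with stated times of 2 h and 24 h, tested at 1 uM (a lower number here means a weaker effect, a higher number a stronger effect of the compound at the concentration tested), compound 1 gives 70.1%, compound 2 gives 65.5% and compound 3 gives 70.1%. Compound 3 stands level with compound 1 at the digits shown, the two together the highest of the three numbers, and the step of a number 4.6 percentage points higher from compound 2 to compound 3 (within the scatter) is within the scatter. The three compounds share one core and differ only in the group carried on the aromatic nitrogen.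

Compound 4 `COc1cccc(-n2nc(-c3ccc(C(F)(F)F)cc3O)nc2-c2ccccc2O)c1` keeps that core and differs from compound 3 in one place: 3-methoxyphenyl in place of 2-chlorophenyl on an aromatic nitrogen.

Within the data shown here, two measured steps bear on this change, since both exchange the group on the aromatic nitrogen: no change at the digits printed from compound 1 to compound 3 (within the scatter) and a number 4.6 percentage points higher from compound 2 to compound 3 (within the scatter). Neither reaches beyond the scatter. With no measured exchange at this position moving the read-out, the expected step of a number 2.1 percentage points lower from compound 3 to compound 4 (within the scatter) is none beyond the scatter. Compound 4 is therefore estimated at 68%, with a range from 57% to 79%.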

Compound 4, a percentage reported as activity, at one concentration (the size of the read-out at that concentration, not a potency): 68.3%
Compound 4: the middle estimate sits 0.3 percentage points below what was measured; low and high end bracket the measured number.
By their numbers in this assay, from the lowest: compounds 2, 4, 1 and 3 (each within the scatter of the next).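

Set against the three earlier groups on the aromatic nitrogen, 3-methoxyphenyl shows no step beyond the scatter in this assay: a number 1.8 percentage points lower from compound 3 to compound 4 (within the scatter), a number 1.8 percentage points lower from compound 1 to compound 4 (within the scatter) and a number 2.8 percentage points higher from compound 2 to compound 4 (within the scatter). Compared with 2-chlorophenyl, this group swaps chlorine for oxygen and brings one hydrogen-bond acceptor, yet that exchange does not separate the two numbers. All four substituted phenyl groups at this position now give values within the scatter of one another, and nothing measured here explains this.

Going by these compounds, all four compounds carry a phenyl ring on this nitrogen, so it remains open what a saturated group such as a cyclohexyl ring or a short alkyl chain would give. Also open, on these data alone, is whether an amine or a carboxylic acid on that phenyl ring would move the read-out beyond the scatter.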